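A Protecting Group Added to Two Triazole Dithiocarbamates

The source may hold more compounds than are shown below. What is called first, only, known or untested is meant among the compounds shown, and "the series" means these compounds.

Compound 1 `S=C(SCc1cn(Cc2ccccc2Cl)nn1)N1CCNCC1` and compound 3 `CC(C)(C)OC(=O)N1CCN(C(=S)SCc2cn(Cc3ccccc3Cl)nn2)CC1` share one core and differ in a single place: tert-butoxycarbonyl in place of hydrogen on an amine nitrogen in a ring. In a functional assay on MCF7 cells (Homo sapiens) for inhibition, read by MTT assay, with a stated time of 72 h (a lower number here means a stronger inhibitor, a higher number a weaker inhibitor), compound 1 gives 38900 nM, while compound 3 gives 6090 nM, which amounts to a 6.4-fold lower number from compound 1 to compound 3 (0.81 log units; beyond the scatter). Compound 2 `COc1cc(Cn2cc(CSC(=S)N3CCNCC3)nn2)cc(OC)c1OC` is built on a different core; how the two cores differ is not broken down here. In this assay compound 2 gives "not determined" (no result reported), so no result is reported for it. Compound 4 `COc1cc(Cn2cc(CSC(=S)N3CCN(C(=O)OC(C)(C)C)CC3)nn2)cc(OC)c1OC` is the not-yet-measured partner of compound 2, and the change between them is the same as that between compound 1 and compound 3: tert-butoxycarbonyl in place of hydrogen on an amine nitrogen in a ring. The surroundings of the place are described in identical words for both pairs, so the change is the same. Compound 2 has no number, so the size of the step from compound 2 to compound 4 cannot be set beside the earlier one. Compound 4 is therefore expected to land near 8000 nM, most likely between 2000 nM and 30000 nM, an estimate anchored only on compound 3 and its value 6090 nM and on the direction of the earlier step of a 6.4-fold lower number from compound 1 to compound 3 (0.81 log units; beyond the scatter).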

Compound 4, half-maximal inhibitory concentration: 22700 nM
Estimate against measurement, compound 4: 2.8-fold (0.45 log units) below; the measured number falls inside the stated range.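

In this assay, going by these compounds alone, compound 4 gives 22700 nM but compound 2 has no number, so no step from compound 2 to compound 4 can be read. The compounds shown leave open whether tert-butoxycarbonyl in place of hydrogen changes the number on this core as it does on the core of compound 1. Nothing shown bears on the cause of this result.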